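Indane amines on a tetrazolylindole piperidine: estimating compound 4

The source may hold more compounds than are shown below. What is called first, only, known or untested is meant among the compounds shown, and "the series" means these compounds.

Measured so far in an assay on CHO cells for agonist activity at 5-hydroxytryptamine receptor 1D (Homo sapiens), read by GTPgammaS binding; on this read-out lower numbers stand for an effect already at smaller amounts and higher numbers for an effect only at larger amounts of compound:
compound 1 `c1ccc(CNC2CCN(CCCc3c[nH]c4ccc(-n5cnnc5)cc34)CC2)cc1` gives 7.6 nM
compound 2 `CC(=O)Nc1ccc([C@H](C)NCC2CCN(CCCc3c[nH]c4ccc(-n5cnnc5)cc34)CC2)cc1` gives 3 nM
compound 3 `O[C@@H]1Cc2ccccc2[C@H]1NC1CCN(CCCc2c[nH]c3ccc(-n4cnnc4)cc23)CC1` gives 13 nM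

Compound 3 stands at the highest number of the three. Its gap to compound 1 is small: a 1.7-fold higher number from compound 1 to compound 3 (0.23 log units; within the scatter), and this lies within the scatter, so the two cannot be ordered. Compound 2, with its acetamidophenyl-ethyl group on an aminomethyl arm, sits at a number beyond the scatter below compound 3.

Compound 4 `c1ccc2c(c1)CCC2NCC1CCN(CCCc2c[nH]c3ccc(-n4cnnc4)cc23)CC1` has not yet been measured. Relative to compound 3 the change is ((2,3-dihydro-1H-inden-1-yl)amino)methyl in place of (2-hydroxy-2,3-dihydro-1H-inden-1-yl)amino on a saturated ring carbon.

Among the measured compounds shown here, only one measured step touches this change: the exchange of benzyl for the hydroxy-indanyl group from compound 1 to compound 3, which stayed within the scatter. That step suggests the indane ring itself is tolerated in this assay. Compound 2 shows that an aminomethyl arm on the piperidine carbon is compatible with a low number, though it is not a single-change comparison with compound 3. Compound 4 is therefore expected to give a number close to compound 3, with at most a modest shift toward lower values, estimated as a 1.9-fold lower number from compound 3 to compound 4 (0.27 log units; within the scatter). Compound 4 is estimated at 7 nM, with a likely range of 2.5 nM to 20 nM.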

Compound 4, half-maximal effective concentration: 1.3 nM
Beside the measured number, compound 4's estimate is 5.4-fold (0.73 log units) above it; measured number below the stated range.
By their numbers in this assay, from the lowest: compound 4; then compound 2; then compounds 1 and 3 (each within the scatter of the next).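

In this assay, replacing (2-hydroxy-2,3-dihydro-1H-inden-1-yl)amino with ((2,3-dihydro-1H-inden-1-yl)amino)methyl on the saturated ring carbon gives a 10-fold lower number from compound 3 to compound 4 (1.00 log units; beyond the scatter) and shows that this position responds to the change, whereas exchanging benzyl for the hydroxy-indanyl group gave only a 1.7-fold higher number from compound 1 to compound 3 (0.23 log units; within the scatter) and stayed within the scatter. The new group also stands clear of the benzylamino group at the same place, with a 5.8-fold lower number from compound 1 to compound 4 (0.77 log units; beyond the scatter) beyond the scatter, and on the amine nitrogen of the aminomethyl arm, 2,3-dihydro-1H-inden-1-yl in place of 1-(4-acetamidophenyl)ethyl gives a 2.3-fold lower number from compound 2 to compound 4 (0.36 log units; beyond the scatter) and shows that the large acetamidophenyl group is not needed for a low number. Nothing at hand explains why the number falls at this position.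

The step from compound 3 to compound 4 removes the hydroxyl and adds the methylene of the arm together, so the compounds shown do not say which of the two accounts for the drop; the 2-hydroxy-2,3-dihydro-1H-inden-1-yl group on the aminomethyl arm would separate them. On these data alone, how an aminoethyl arm, or a single defined stereoisomer of the indanyl amine, would read in this assay also stays open.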